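Replacing a methoxyphenyl arm on a shared core

A few compounds are considered here, and "the series" means these few. Any claim that something is new, unique, unknown or untested is made for them only; others in the source may bear on it.

Measured so far, in a functional assay on MCF7 cells (Homo sapiens) for cytotoxicity, read by MTT assay, with a stated time of 72 h; on this read-out lower numbers stand for stronger inhibition and higher numbers for weaker inhibition:
- compound 1, `COc1cccc(/C=C2\CCC/C(=C\c3ccccc3Br)C2=O)c1OC`, gives 9700 nM
- compound 2, `COc1cccc(/C=C2\CCC/C(=C\c3cc(OC)c(OC)c(OC)c3)C2=O)c1OC`, gives 1400 nM
- compound 3, `COc1ccccc1/C=C1\CCC/C(=C\c2ccc(OC)c(OC)c2)C1=O`, gives 8000 nM

All three share one core and differ only in the two aromatic arms attached to it. Compound 3 stands second highest of the three numbers. Its nearest neighbour is compound 1, whose number is within the scatter of that of compound 3, so the two cannot be ordered. Within the data shown here, the one clearly different number belongs to compound 2, which lies beyond the scatter below compound 3.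

Compound 4, `COc1cc(/C=C2\CCC/C(=C\c3ccc(OC)c(OC)c3)C2=O)ccc1O`, has not yet been measured. It differs from compound 3 in one place: 4-hydroxy-3-methoxyphenyl in place of 2-methoxyphenyl on a double-bonded chain carbon bound to a double-bonded ring carbon. Among the measured compounds shown here, no pair of measured compounds differing in a single place is available, so the size of this step has to be guessed from the spread of the three numbers alone. The step from compound 3 to compound 4 is expected to be small and downward, likely no larger than the scatter, as a 1.8-fold lower number from compound 3 to compound 4 (0.25 log units; within the scatter).

Compound 4 is therefore expected to give about 4500 nM in this assay, within a range from 1500 nM to 13000 nM.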

Compound 4, half-maximal inhibitory concentration: 7900 nM
Compound 4: the middle estimate sits 1.8-fold (0.24 log units) below what was measured; measured number inside the range.
By their numbers in this assay, from the lowest: compound 2; then compounds 4, 3 and 1 (each within the scatter of the next).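

Among these compounds, replacing 2-methoxyphenyl with 4-hydroxy-3-methoxyphenyl on a double-bonded chain carbon bound to a double-bonded ring carbon gives, in this assay, a 1.0-fold lower number from compound 3 to compound 4 (0.01 log units; within the scatter), and this is the only comparison in the set that differs in a single place. It shows that, with this second arm in place, the position accepts an arm of 9 heavy atoms in place of 8, with 1 hydrogen-bond donor in place of 0, without a readable difference in the cytotoxicity number. No measurement is available that bears on why these two numbers match.

This single swap adds a hydroxy group and rearranges the methoxy pattern of the arm at once, so the compounds shown cannot separate what each part contributes, and they cannot show whether the result would hold with a different second arm on the shared core. On these data alone, it also remains open how this position would respond to an arm carrying an amine or a carboxylic acid.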